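Moving the ring nitrogen on an inactive piperazine amide

The source may hold more compounds than are shown below. What is called first, only, known or untested is meant among the compounds shown, and "the series" means these compounds.

Measured so far:
Compound 1 `Cc1cc(C)c2cc(C#N)c(NCCNC(=O)c3ccccc3)nc2c1`: "not active" (no number reported)
Compound 2 `COc1ccc(C(=O)NCCNc2nc3cc(C)cc(C)c3cc2C#N)c(OC)c1`: 4200 nM
Compound 3 `Cc1cc(C)c2cc(C#N)c(N3CCN(C(=O)c4ccccn4)CC3)nc2c1`: "not active" (no number reported)

Three compounds share a core and differ in the amide-bearing side chain. In an in vitro assay on FRT cells with Cystic fibrosis transmembrane conductance regulator variant F508del (Homo sapiens) as the target, read by fluorescence, with a stated time of 24 h, at 37 degrees C, in the presence of a further agent that is not named here (on this read-out higher numbers stand for an effect only at larger amounts of compound and lower numbers for an effect already at smaller amounts), compound 1 `Cc1cc(C)c2cc(C#N)c(NCCNC(=O)c3ccccc3)nc2c1` is recorded as "not active" (no number reported), without a number. In this assay compound 2 `COc1ccc(C(=O)NCCNc2nc3cc(C)cc(C)c3cc2C#N)c(OC)c1` gives 4200 nM, the only numerical result among the three. Among the compounds with values here, compound 3 `Cc1cc(C)c2cc(C#N)c(N3CCN(C(=O)c4ccccn4)CC3)nc2c1`, which carries the piperazine-linked pyridin-2-yl amide, is likewise recorded as "not active" (no number reported) in this assay, so it stands with compound 1 among the compounds for which no concentration was reported, and no measured step connects it to compound 2.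

Compound 4 `Cc1cc(C)c2cc(C#N)c(N3CCN(C(=O)c4cccnc4)CC3)nc2c1` is the next member: pyridin-3-yl in place of pyridin-2-yl on a carbonyl carbon. Within the data shown here, since compound 3 gave no number in this assay, no step between the two can be stated; the two structures have the same atoms joined differently, and the author expects the change to make no difference beyond the scatter, with compound 4 most likely also returning no number. Should this assay yield a value, compound 4 is estimated at 15000 nM, within 4000 nM to 50000 nM.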

Compound 4, half-maximal effective concentration: "not active" (no number reported)
For compound 4 the study gives words and no number, and the estimate cannot be compared.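

In this assay, within the data shown here, compound 3 and compound 4 are both recorded without a number, so no step between them can be read. The compounds shown leave open whether pyridin-3-yl in place of pyridin-2-yl changes the effect at all. No measured evidence bears on these results.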